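The source may hold more compounds than are shown below. What is called first, only, known or untested is meant among the compounds shown, and "the series" means these compounds.

Compound 1 `CCn1nc(S(=O)(=O)c2cccc3ccccc23)c2cc(N3CCN(C)CC3)ccc21` gives 100% in a functional assay on HeLa cells for antagonist activity at 5-hydroxytryptamine receptor 6 (Homo sapiens) (a higher number here means a larger maximal response, a lower number a smaller maximal response), a full response against the reference. Compound 2 `CN1CCN(c2ccc3[nH]nc(S(=O)(=O)c4ccc(Cl)cc4)c3c2)CC1` gives 100% and compound 3 `COc1ccc(S(=O)(=O)c2n[nH]c3ccc(N4CCN(C)CC4)cc23)cc1` gives 100% in this assay, so compound 1 stands level with both at the digits printed, within the scatter of the method. Among the compounds with values here, the one single-point step measured so far, no change at the digits printed from compound 2 to compound 3 (within the scatter), is flat: methoxy in place of chloro on an aromatic carbon leaves the maximal response where it was.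

Compound 4 `CN1CCN(c2ccc3c(c2)c(S(=O)(=O)c2cccc4ccccc24)nn3Cc2ccccc2)CC1` differs from compound 1 by phenyl in place of methyl on a saturated chain carbon bound to an aromatic nitrogen; cut one bond further out the same difference reads ethyl to benzyl. Within the data shown here, no measured step touches a saturated chain carbon bound to an aromatic nitrogen, so the flat step from compound 2 to compound 3 is the only guide and it concerns a different place. With all three measured compounds at the same ceiling, the expectation for compound 4 is no step beyond the scatter, no change at the digits printed from compound 1 to compound 4 (within the scatter). Compound 4 is therefore estimated at 100% in this assay, with a range of 90% to 105%.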

Compound 4, largest response reached (reported as Imax), in percent of the reference or control that the assay uses: 100%
The estimate for compound 4 equals the measured number at the digits printed; the measured number falls inside the stated range.
By their numbers in this assay, from the lowest: compounds 1, 2, 3 and 4 (each within the scatter of the next).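

The saturated chain carbon bound to an aromatic nitrogen now has a measured step of its own: in this assay, phenyl in place of methyl at this place, which reads ethyl to benzyl when cut one bond further out, gives no change at the digits printed from compound 1 to compound 4 (within the scatter). On the naphthyl sulfone of compound 1, the group entering here can therefore go from 1 heavy atom to 6 heavy atoms, including one six-membered aromatic ring of carbon only, and the maximal response stays level. Nothing at hand bears on why the response holds at this position.

Going by these compounds, whether a longer chain such as phenethyl, or a chain ending in an amine or a carboxylic acid, would hold the response at this place remains open. All four compounds stand level, so the compounds shown do not reveal which change, if any, would move this read-out beyond the scatter.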